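Halogen to trifluoromethyl on the fused ring: cytotoxicity notes

The source may hold more compounds than are shown below. What is called first, only, known or untested is meant among the compounds shown, and "the series" means these compounds.

Of the compounds shown here, two carry a number so far. Compound 1 `O=c1cc(-c2ccccc2)oc2cc(OCCCCNc3nc4ccc(Br)cc4s3)cc(O)c12` and compound 2 `O=c1cc(-c2ccccc2)oc2cc(OCCCCNc3nc4ccc(F)cc4s3)cc(O)c12` differ only in the halogen on the fused ring; in an ADME assay on MDCK cells (Canis lupus familiaris) for cytotoxicity, read by sulforhodamine B assay, with a stated time of 48 h (a higher number here means a weaker inhibitor, a lower number a stronger inhibitor), compound 1 gives 289 ug/mL and compound 2 gives 324 ug/mL. Going by the values given here, the single step between them, a 1.1-fold higher number from compound 1 to compound 2 (0.05 log units; within the scatter), falls within the scatter. Compound 2 thus stands at the upper figure of the pair, yet is not separated from compound 1 beyond the scatter.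

Compound 3 `O=c1cc(-c2ccccc2)oc2cc(OCCCCNc3nc4ccc(C(F)(F)F)cc4s3)cc(O)c12` is the next variation at the same position: trifluoromethyl in place of fluoro on an aromatic carbon. Among the compounds with values here, the only measured step that bears on this place is the bromo-to-fluoro exchange, and it was within the scatter, so the evidence from the series points to no step beyond the scatter in this assay; no measured step with a trifluoromethyl group exists to sharpen that. Compound 3 is therefore expected to give about 300 ug/mL in this assay, with a range of 150 ug/mL to 600 ug/mL, meaning an expected step of a 1.1-fold lower number from compound 2 to compound 3 (0.03 log units; within the scatter).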

Compound 3, half-maximal inhibitory concentration: 278 ug/mL
For compound 3 the middle estimate is 1.1-fold (0.03 log units) above the measured one; measured number inside the range.
By their numbers in this assay, from the lowest: compounds 3, 1 and 2 (each within the scatter of the next).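

Trifluoromethyl is the first group at this place on the fused ring that is not a single halogen atom, and the reading in this assay still does not separate it from either halogen (a 1.2-fold lower number from compound 2 to compound 3 (0.07 log units; within the scatter); a 1.0-fold lower number from compound 1 to compound 3 (0.02 log units; within the scatter)). The earlier pair showed only that bromo and fluoro could be exchanged without a step beyond the scatter; the series now shows the same for a group with a carbon attached to the ring, so that bromo, fluoro and trifluoromethyl on this aromatic carbon give one flat set of numbers, with no order among compounds 1, 2 and 3. No measurement in hand offers an explanation for this flatness.

Open, as far as these compounds go, is whether the flat reading extends to groups of another kind at the same place, such as an amine, a carboxylic acid or a methoxy group, or whether one of these would give a step beyond the scatter. Also open, from the compounds shown here alone, is what a longer chain in place of the present linking chain would do in this assay, as compounds 1, 2 and 3 all carry the same one.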